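This account rests on a few compounds, and the source may have more. Where it says the series, first, only, none or still open, it means among the compounds named here.

Of the compounds shown here, three share one core and have been measured in an assay on isolated protein (strain Sprague-Dawley) for inhibition of Amine oxidase [flavin-containing] A (Rattus norvegicus), read by spectrophotometry, with a stated time of 5 min; a lower number here means a stronger inhibitor, a higher number a weaker inhibitor. Compound 1 `NC(=O)COc1cc(=O)oc2cc(OCc3cccc(Br)c3)ccc12` gives 8910 nM. Compound 2 `O=c1cc(Cl)c2ccc(OCc3cccc(Cl)c3)cc2o1` gives 8910 nM, level with compound 1 at the digits shown, and these two stand together as the highest of the three numbers. Among the measured compounds shown here, compound 3 `Nc1cc(=O)oc2cc(OCc3cccc(Cl)c3)ccc12` gives 4170 nM, and the step of a 2.1-fold lower number from compound 2 to compound 3 (0.33 log units; beyond the scatter) is the one measured change that bears on the question here. Compound 4 `CNc1cc(=O)oc2cc(OCc3cccc(Cl)c3)ccc12` differs from compound 2 by methylamino in place of chloro on an aromatic carbon. Since the closely related exchange for amino gave a 2.1-fold lower number from compound 2 to compound 3 (0.33 log units; beyond the scatter), compound 4 is expected to sit near compound 3 rather than compound 2, a modest drop in this assay. The expected step is a 2.2-fold lower number from compound 2 to compound 4 (0.35 log units; beyond the scatter). Compound 4 is estimated at 4000 nM, within 1500 nM to 11000 nM.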

Compound 4, half-maximal inhibitory concentration: 4070 nM
Beside the measured number, compound 4's estimate is 1.0-fold (0.01 log units) below it; measured number inside the range.
By their numbers in this assay, from the lowest: compounds 4 and 3 (each within the scatter of the next); then compounds 1 and 2 (each within the scatter of the next).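

On the aromatic carbon opposite the ring oxygen, a second nitrogen group now replaces chloro, and methylamino gives a 2.2-fold lower number from compound 2 to compound 4 (0.34 log units; beyond the scatter) as a modest step, so the earlier gain with amino is not confined to that one group. Methyl in place of hydrogen on that nitrogen gives a 1.0-fold lower number from compound 3 to compound 4 (0.01 log units; within the scatter) and cannot be told apart from no difference. From the compounds shown here alone, how ethylamino, with its longer chain, or dimethylamino, with no hydrogen left on the nitrogen, would read at this position stays open. No measurement here explains these numbers.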